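Ethylamino to propylamino: compound 3 to compound 4

The source may report more compounds than this note shows. Statements on the series, on what has been measured and on what is new or still open speak of the compounds shown alone.

In a functional assay on the whole organism for inhibition, with Mus musculus as the target (a higher number here means that more compound is needed for the effect, a lower number that less compound is needed), compound 1 (`CN1Cc2c(N)cccc2C(c2ccc(Cl)cc2)C1`) gives 1.6 mg/kg and compound 2 (`Cc1ccc(C2CN(C)Cc3c(N)cccc32)cc1`) gives 1.6 mg/kg on the same read-out. In this assay compound 3 (`CCNC(=O)Nc1cccc2c1CN(C)CC2c1ccccc1`) gives 80 mg/kg and stands highest of the three numbers, beyond the scatter from both compound 1 and compound 2.

Compound 4 (`CCCNC(=O)Nc1cccc2c1CN(C)CC2c1ccccc1`) carries one change against compound 3 (methyl in place of hydrogen on a saturated chain carbon, two bonds along the chain from an amide-type nitrogen): methyl in place of hydrogen on a saturated chain carbon, two bonds along the chain from an amide-type nitrogen, so that ethylamino becomes propylamino.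

Going by the values given here, only one measured step is available, no change at the digits printed from compound 1 to compound 2 (within the scatter) for methyl in place of chloro on an aromatic carbon. That step is a weak guide, since it lies at another place and neither of its compounds carries the ethylamino chain. Among the compounds with values here, no measured step alters the chain itself, and the data give no direct size for this change. The estimate therefore rests on compound 3 at 80 mg/kg as its starting point.

The expected outcome is no change at the digits printed from compound 3 to compound 4 (within the scatter) in this assay with no shift beyond the scatter foreseen in either direction. For compound 4 the estimate is 80 mg/kg with 30 mg/kg to 200 mg/kg as the expected range.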

Compound 4, dose for half-maximal effect: > 80 mg/kg
Compound 4: a limit, no number; the forecaster's own chance of this, stated with the estimate: 25%; the middle value lies on the limit itself.
By their numbers in this assay, from the lowest: compounds 1 and 2 (each within the scatter of the next); then compound 3.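

In this assay compound 4 gives > 80 mg/kg, which is a limit of the assay and not a number. The step from ethylamino to propylamino gives a number no lower from compound 3 to compound 4 (the limit leaves the size open), and its size cannot be read because of that limit: the limit of > 80 mg/kg in this assay, at which 1 of the 4 values shown sits. Going by these compounds alone, the only earlier one-place step, methyl in place of chloro on an aromatic carbon, showed no change at the digits printed from compound 1 to compound 2 (within the scatter), so this is the first reading at a saturated chain carbon, two bonds along the chain from an amide-type nitrogen, and there the added methyl brings no drop in the dose needed.

The compounds shown leave open how far the number rises with propylamino, and whether a shorter methylamino group or a longer butylamino chain at this place would give a number that can be read in this assay. They also leave open whether the chloro or methyl group of compounds 1 and 2 would alter the reading on a compound carrying the ethylamino chain.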